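This account rests on a few compounds, and the source may have more. Where it says the series, first, only, none or still open, it means among the compounds named here.

Of the compounds shown here, two from this study have been measured, and a third awaits its number. Compound 1, `C#CCSc1nc(Nc2ccc(Cl)cc2)c(C#N)c(-c2ccccc2)n1`, carries a propargyl thioether on the shared core. In a functional assay on ECa-109 cells (Homo sapiens) for inhibition, read by MTT assay, with a stated time of 72 h (a higher number here means a weaker inhibitor, a lower number a stronger inhibitor), compound 1 gives no number but only a limit of the assay, > 128000 nM. Compound 2, `COc1ccc(Nc2nc(SCc3cn(Cc4ccccc4Cl)nn3)nc(-c3ccccc3)c2C#N)cc1`, replaces that thioether with a larger triazole-bearing one and carries a (4-methoxyphenyl)amino group; in this assay compound 2 gives 7960 nM. Compound 2 thus holds the only real number shown, while the other value is a limit, as recorded in the limit of > 128000 nM in this assay, at which 1 of the 2 values shown sits.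

Compound 3, `N#Cc1c(Nc2ccc(Cl)cc2)nc(SCc2cn(Cc3ccccc3Cl)nn2)nc1-c1ccccc1`, differs from compound 2 in one place: chloro in place of methoxy on an aromatic carbon, turning (4-methoxyphenyl)amino into (4-chlorophenyl)amino. Going by the values given here, no measured pair shows this swap alone. The step from compound 2 to compound 3 is expected to be small, a 1.5-fold higher number from compound 2 to compound 3 (0.18 log units; within the scatter), leaning toward weaker inhibition but not clearly beyond the usual scatter. For compound 3 the estimated value in this assay is 12000 nM, with a likely range from 4000 nM to 40000 nM.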

Compound 3, half-maximal inhibitory concentration: 1420 nM
Compound 3: the middle estimate sits 8.5-fold (0.93 log units) above what was measured; measured number below the stated range.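

Swapping methoxy for chloro on this aromatic carbon, para to a large group, is not a neutral change in this assay: the swap gives a 5.6-fold lower number from compound 2 to compound 3 (0.75 log units; beyond the scatter). Going by these compounds alone, this is the first step here between two compounds that differ in one place, with a real number at both ends, and it shows that the result responds to what sits at this position. Compound 1 carries the same (4-chlorophenyl)amino group with a propargyl thioether in place of the triazole-bearing one, and it gives only a limit of the assay, so this group does not yield a measurable number on its own: the limit of > 128000 nM in this assay, at which 1 of the 3 values shown sits.

The compounds shown hold only methoxy and chloro at this position, so how a fluoro, a methyl or an amine would read there remains open. Also open, from the compounds shown here alone, are why chloro gives the lower number, which a single step cannot tell, and whether the same swap would give a similar step with a different thioether on the shared core.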